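This account rests on a few compounds, and the source may have more. Where it says the series, first, only, none or still open, it means among the compounds named here.

Measured in an assay on isolated protein for inhibition of aldehyde dehydrogenase 1A1 (Homo sapiens), read by spectrophotometry, tested at 10 uM; a lower number here means less inhibition, a higher number more inhibition at the concentration tested (going by the name of the read-out):
compound 1, `O=C(C1CC1)N1CCN(Cc2nc3ccccc3n2Cc2ccccc2F)CC1`: 40.7%
compound 2, `Cc1cccc(Cn2c(CN3CCN(C(=O)c4ccc(C(C)C)cc4)CC3)nc3ccccc32)c1`: 67.6%
compound 3, `Cc1cccc(Cn2c(CN3CCN(C(=O)C4CCCCC4)CC3)nc3ccccc32)c1`: 31.9%

Compound 1 stands second highest of the three numbers in this assay; its gap to compound 3 lies within the scatter, its gap to compound 2 beyond it. Within the data shown here, the only one-place step measured, a number 35.7 percentage points lower from compound 2 to compound 3 (beyond the scatter), alters the group on the carbonyl carbon, and compounds 2 and 3 both carry a 3-methylbenzyl rather than the 2-fluorobenzyl of compound 1, so no measured step bears on the change to compound 4, `COc1cccc(Cn2c(CN3CCN(C(=O)C4CC4)CC3)nc3ccccc32)c1`: 3-methoxyphenyl in place of 2-fluorophenyl on a saturated chain carbon bound to an aromatic nitrogen. Among the measured compounds shown here, with no comparable step in hand, the expected change in this assay is a number 0.7 percentage points lower from compound 1 to compound 4 (within the scatter), none beyond the scatter, and the estimate for compound 4 is accordingly 40%, in the range 20% to 62%.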

Compound 4, a percentage reported as inhibition, at one concentration (the size of the read-out at that concentration, not a potency): 44.4%
Beside the measured number, compound 4's estimate is 4.4 percentage points below it; measured number inside the range.
By their numbers in this assay, from the lowest: compounds 3, 1 and 4 (each within the scatter of the next, the first and the last beyond it); then compound 2.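

In this assay the group on a saturated chain carbon bound to an aromatic nitrogen, changed from 2-fluorophenyl to 3-methoxyphenyl, gives a number 3.7 percentage points higher from compound 1 to compound 4 (within the scatter) and so leaves the two groups unseparated. This swap also takes the hydrogen-bond acceptor count of the group from 0 to 1 with no reading beyond the scatter. No measurement on hand speaks to the reason for this result.

The compounds shown do not separate the effect of the substituent from that of its ring position. From the compounds shown here alone, whether an amine or a carboxylic acid on this phenyl moves the number remains open.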